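This account rests on a few compounds, and the source may have more. Where it says the series, first, only, none or still open, it means among the compounds named here.

Measured so far in a functional assay on HCT-116 cells (Homo sapiens) for antiproliferative activity, read by MTT assay; on this read-out lower numbers stand for stronger inhibition and higher numbers for weaker inhibition:
compound 1 `Cn1c(=O)c(=O)n(C2CCCC2)c2nc(N/N=C/c3ccc(Cl)cc3)ncc21`: 9810 nM
compound 2 `Cn1c(=O)c(=O)n(C2CCCC2)c2nc(N/N=C/c3ccc(O)c(F)c3)ncc21`: 59300 nM
compound 3 `Cn1c(=O)c(=O)n(C2CCCC2)c2nc(N/N=C/c3ccc(C(F)(F)F)cc3)ncc21`: 29000 nM

Compound 3, at 29000 nM, holds the middle place of the three, weaker than compound 1 and stronger than compound 2.

Next is compound 4 `Cn1c(=O)c(=O)n(C2CCCC2)c2nc(N/N=C/c3ccco3)ncc21`, with the change (furan-2-yl in place of 4-(trifluoromethyl)phenyl on a carbon with a double bond to nitrogen), in words furan-2-yl in place of 4-(trifluoromethyl)phenyl on a carbon with a double bond to nitrogen. Among the measured compounds shown here, no measured compound carries a five-membered aromatic ring at this place, so no step speaks to it directly. The nearest evidence is the set of changes on the same aromatic group: a 3.0-fold higher number from compound 1 to compound 3 (0.47 log units; beyond the scatter), a 2.0-fold lower number from compound 2 to compound 3 (0.31 log units; beyond the scatter) and a 6.0-fold higher number from compound 1 to compound 2 (0.78 log units; beyond the scatter). All are modest, though beyond the scatter, and they suggest a size but no direction for the new group. A modest move either way in this assay remains possible, but the central expectation is no step beyond the scatter. The expected step is a 1.2-fold lower number from compound 3 to compound 4 (0.06 log units; within the scatter). For compound 4 the estimated value is 25000 nM, with an expected range of 8000 nM to 70000 nM.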

Compound 4, half-maximal inhibitory concentration: 78700 nM
Beside the measured number, compound 4's estimate is 3.1-fold (0.50 log units) below it; measured number outside the range, above it.
By their numbers in this assay, from the lowest: compound 1; then compound 3; then compounds 2 and 4 (each within the scatter of the next).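

In this assay, the five-membered furan-2-yl on the carbon with a double bond to nitrogen brings no gain over either 4-substituted phenyl group without a hydroxyl, with a weaker result against 4-(trifluoromethyl)phenyl (a 2.7-fold higher number from compound 3 to compound 4 (0.43 log units; beyond the scatter)) and a larger drop against 4-chlorophenyl (an 8.0-fold higher number from compound 1 to compound 4 (0.90 log units; beyond the scatter)), so compound 1 stays the strongest of the four. Against 3-fluoro-4-hydroxyphenyl, furan-2-yl shows no separation (a 1.3-fold higher number from compound 2 to compound 4 (0.12 log units; within the scatter)), so two quite different groups at this place land at the same level. Nothing available accounts for these steps.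

Open, from the compounds shown here alone, is whether the drop from 4-chlorophenyl belongs to the furan ring itself, which a thiophene or an unsubstituted phenyl would help to settle. Also open, going by these compounds, is how an amine or a carboxylic acid on the phenyl ring would read in this assay.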